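This account rests on a few compounds, and the source may have more. Where it says the series, first, only, none or still open, it means among the compounds named here.

Measured so far in a functional assay on CWR22R cells (Homo sapiens) for antiproliferative activity, read by propidium iodide staining, with a stated time of 96 h; on this read-out higher numbers stand for weaker inhibition and lower numbers for stronger inhibition:
- compound 1 `CC(O)(CSc1ccc(S(F)(F)(F)(F)F)cc1)C(=O)Nc1ccc(C#N)c(C(F)(F)F)c1` gives 18100 nM
- compound 2 `CC(O)(CSc1cccc(S(F)(F)(F)(F)F)c1)C(=O)Nc1ccc(C#N)c(C(F)(F)F)c1` gives 20400 nM
- compound 3 `CC(O)(CSc1ccc(S(F)(F)(F)(F)F)cc1)C(=O)Nc1ccc([N+](=O)[O-])c(C(F)(F)F)c1` gives 9200 nM

Compound 2 (20400 nM) lies within the scatter of compound 1 (18100 nM), and its number is clearly higher than that of compound 3 (9200 nM). Compound 4 `CC(O)(CSc1cccc(S(F)(F)(F)(F)F)c1)C(=O)Nc1ccc([N+](=O)[O-])c(C(F)(F)F)c1` has not been measured. It differs from compound 2 in one place: nitro in place of cyano on an aromatic carbon with nitro in place of cyano on an aromatic carbon, ortho to a trifluoromethyl group. For the measured compounds named here, the same swap was measured once, and it gave a 2.0-fold lower number from compound 1 to compound 3 (0.29 log units; within the scatter) in this assay and no other step bears on it. That single step is thin evidence, so only a modest shift towards stronger inhibition is expected, and it may not clear the scatter. The expected change is a 1.9-fold lower number from compound 2 to compound 4 (0.27 log units; within the scatter) in this estimate. The estimated value for compound 4 is 11000 nM (expected range 6000 nM to 20000 nM).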

Compound 4, half-maximal inhibitory concentration: 8800 nM
For compound 4 the middle estimate is 1.3-fold (0.10 log units) above the measured one, within the range that was stated.
By their numbers in this assay, from the lowest: compounds 4, 3, 1 and 2 (each within the scatter of the next, the first and the last beyond it).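

In this assay, nitro in place of cyano gives a 2.3-fold lower number from compound 2 to compound 4 (0.37 log units; beyond the scatter) on this core, a step that clears the scatter, which the earlier pair alone did not do. The swap on an aromatic carbon, ortho to a trifluoromethyl group, therefore points the same way on both cores, and the two steps agree in size: the same change on two cores in this assay, a 2.0-fold lower number (0.29 log units; within the scatter) from compound 1 to compound 3 and a 2.3-fold lower number (0.37 log units; beyond the scatter) from compound 2 to compound 4, 1.2-fold (0.07 log units) apart, within the scatter of two such steps

The compounds shown leave open whether any other group at this position, such as an amine or a carboxylic acid, would go beyond nitro. They also cannot say why nitro differs from cyano here.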